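Pyridazinone series: the meta substituent and 5-lipoxygenase inhibition

The source may report more compounds than this note shows. Statements on the series, on what has been measured and on what is new or still open speak of the compounds shown alone.

Measured so far:
compound 1 `O=C1CCCN(c2cccc(Cl)c2)N1`, 2500 nM
compound 2 `O=C1CCCN(c2cccc(CO)c2)N1`, 53000 nM

In an assay on isolated protein for inhibition of Polyunsaturated fatty acid 5-lipoxygenase (Homo sapiens) (a lower number here means a stronger inhibitor, a higher number a weaker inhibitor), compound 1 gives 2500 nM. Compound 2, which carries hydroxymethyl in place of chloro on the same aromatic carbon, gives 53000 nM in this assay, the higher of the two numbers recorded; the step of a 21-fold higher number from compound 1 to compound 2 (1.33 log units; beyond the scatter) is a large one.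

Compound 3 `CC(C)(C)C(=O)c1cccc(N2CCCC(=O)N2)c1` is not yet measured. It differs from compound 2 by (tert-butyl)carbonyl in place of hydroxymethyl on an aromatic carbon. Within the data shown here, no measured step covers the entering (tert-butyl)carbonyl. Among the measured compounds shown here, the only step available, a 21-fold higher number from compound 1 to compound 2 (1.33 log units; beyond the scatter), concerns the same position and shows that hydroxymethyl there went with a much weaker number than chloro, so removing hydroxymethyl is the part of the change on which the data speak; what the entering group adds is unknown from these two compounds.

On that basis compound 3 is expected to give a lower number than compound 2, with the step estimated as a 6.6-fold lower number from compound 2 to compound 3 (0.82 log units; beyond the scatter). The estimate for compound 3 in this assay is 8000 nM, with a range from 1500 nM to 40000 nM.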

Compound 3, half-maximal inhibitory concentration: 15000 nM
The estimate for compound 3 lay 1.9-fold (0.27 log units) below the measured number; the range from low to high includes it.
By their numbers in this assay, from the lowest: compound 1; then compound 3; then compound 2.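

In this assay, the step of a 3.5-fold lower number from compound 2 to compound 3 (0.55 log units; beyond the scatter) shows that a lower number at this aromatic carbon does not depend on chloro alone, since (tert-butyl)carbonyl, which has no hydrogen-bond donor, also improves on hydroxymethyl. The step of a 6.0-fold higher number from compound 1 to compound 3 (0.78 log units; beyond the scatter) places this group short of chloro, so the order among the three groups at this place runs chloro, then (tert-butyl)carbonyl, then hydroxymethyl, with each gap beyond the scatter. No measured data on hand account for this order.

The (tert-butyl)carbonyl change leaves open how much of the step belongs to the carbonyl and how much to the tert-butyl, and a plain tert-butyl or an acetyl group on the same aromatic carbon would separate the two. Also open, from the compounds shown here alone, is how far the order extends to other kinds of group at this place, such as fluoro, methoxy, an amine or a carboxylic acid, and whether any of them reaches or passes chloro on the shared core.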